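The compounds below may be only part of what the source reports. "The series", "measured", "known", "first", "only" and "open" are said of these compounds alone.

Compound 1, `O=C([C@@H]1CCCN(S(=O)(=O)c2ccc(S(=O)(=O)C3CCC3)cc2)C1)N1CCC(F)(F)CC1`: in a functional assay on MIA PaCa-2 cells (Homo sapiens) for inhibition, read by MTT assay, with a stated time of 3 days (a higher number here means a weaker inhibitor, a lower number a stronger inhibitor), compound 1 gives > 3000 nM, which is a limit of the assay and not a number.
Compound 2, `CC(C)S(=O)(=O)c1ccc(S(=O)(=O)N2CCC[C@@H](C(=O)N3CCC(F)(F)CC3)C2)cc1`: in this assay compound 2 gives > 3000 nM, again a limit rather than a number.

Compound 2 therefore stands only at a limit in this assay; no number places it more exactly. Among the measured compounds shown here, the single measured step, a step that the two limits leave unreadable from compound 1 to compound 2, cannot be read because both of its ends sit at the limit of > 3000 nM in this assay, at which 2 of the 2 values shown sit.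

Compound 3, `CN(C)S(=O)(=O)c1ccc(S(=O)(=O)N2CCC[C@@H](C(=O)N3CCC(F)(F)CC3)C2)cc1`, differs from compound 2 in one place: dimethylamino in place of isopropyl on a sulfonyl sulfur. For the measured compounds named here, the only measured step that bears on this position is a step that the two limits leave unreadable from compound 1 to compound 2, and its size is not readable, so it gives neither a direction nor a magnitude to build on. Both measured compounds sit at the limit, and the change in compound 3 is of the same small kind as the one between them, so the most likely outcome is that compound 3 also stays at the limit. Compound 3 is therefore expected to give about 6000 nM in this assay, most plausibly between 2000 nM and 30000 nM. This amounts to an expected step that the limit leaves unreadable from compound 2 to compound 3, an estimate and not a measurement.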

Compound 3, half-maximal inhibitory concentration: > 3000 nM
Compound 3: no number, only a limit; the forecaster's own chance of this, stated with the estimate: 80%; the middle value does not contradict the limit.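

In this assay compound 3 gives > 3000 nM as a limit and not a number. The steps to compound 3 from compound 1 and from compound 2 therefore cannot be read, since all three compounds sit at one limit: (the limit of > 3000 nM in this assay, at which 3 of the 3 values shown sit). The compounds shown leave open how far each lies from that limit.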